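Moving a Trifluoromethoxy Group on Two Related Anilide Sulfones

The source may report more compounds than this note shows. Statements on the series, on what has been measured and on what is new or still open speak of the compounds shown alone.

Compound 1, `CC(O)(CS(=O)(=O)c1ccc(OC(F)(F)F)cc1)C(=O)Nc1ccc(S(F)(F)(F)(F)F)cc1`, gives 92800 nM in a functional assay on LNCaP cells (Homo sapiens) for antiproliferative activity, read by propidium iodide staining, with a stated time of 96 h; a lower number here means a stronger inhibitor, a higher number a weaker inhibitor.
Compound 2, `CC(O)(CS(=O)(=O)c1cccc(OC(F)(F)F)c1)C(=O)Nc1ccc(S(F)(F)(F)(F)F)cc1`, gives 21700 nM in this assay.
Compound 3, `CC(O)(CS(=O)(=O)c1ccc(OC(F)(F)F)cc1)C(=O)Nc1cccc(S(F)(F)(F)(F)F)c1`, gives 10700 nM in this assay.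

Compounds 1 and 2 share one core and differ in a single place: 3-(trifluoromethoxy)phenyl in place of 4-(trifluoromethoxy)phenyl on a sulfonyl sulfur. That change alone produced a 4.3-fold lower number from compound 1 to compound 2 (0.63 log units; beyond the scatter), a step that goes beyond the usual scatter of the measurement. Compound 3 is built on a different core; the difference between the two cores is not broken down here. Compound 3 has the lowest number of the three measured compounds, and compound 2 stands nearest to it with 21700 nM.

Compound 4, `CC(O)(CS(=O)(=O)c1cccc(OC(F)(F)F)c1)C(=O)Nc1cccc(S(F)(F)(F)(F)F)c1`, has not yet been measured. It stands to compound 3 as compound 2 stands to compound 1: 3-(trifluoromethoxy)phenyl in place of 4-(trifluoromethoxy)phenyl on a sulfonyl sulfur. The surroundings of the change are described in the same words in both pairs, so this is the same change made on the second core. The step from compound 3 to compound 4 is expected to be a 3.6-fold lower number from compound 3 to compound 4 (0.55 log units; beyond the scatter), similar in direction to the earlier step, because a 4.3-fold lower number from compound 1 to compound 2 (0.63 log units; beyond the scatter) was seen for the same change. Within the data shown here, since only one example of the change is available, the expected size carries clear uncertainty. Compound 4 is therefore estimated at 3000 nM, with a range from 1000 nM to 9000 nM.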

Compound 4, half-maximal inhibitory concentration: 15100 nM
Estimate against measurement, compound 4: 5.0-fold (0.70 log units) below; the measured number lies above the stated range.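

On the second core, swapping 4-(trifluoromethoxy)phenyl for 3-(trifluoromethoxy)phenyl on the sulfonyl sulfur gave a 1.4-fold higher number from compound 3 to compound 4 (0.15 log units; within the scatter), so the two compounds cannot be told apart in this assay. The clear gain in the core of compound 1 therefore did not carry over to the core of compound 3, and the gap between the two results is larger than measurement scatter alone would explain: the same change on two cores in this assay, a 4.3-fold lower number (0.63 log units; beyond the scatter) from compound 1 to compound 2 and a 1.4-fold higher number (0.15 log units; within the scatter) from compound 3 to compound 4, 6.0-fold (0.78 log units) apart, beyond the scatter of two such steps. Among these compounds, this shows that, in this small series, the effect of the change depends on the core it is made on, but it does not show why, and with only one pair on each core it gives no rule for what a third core would do.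

Still open, as far as these compounds go, is whether the same shift of position would also depend on the core if a methoxy group, a chlorine atom or a nitrile took the place of the trifluoromethoxy group. From the compounds shown here alone, it is also open whether the two cores would respond differently to this change in any measurement other than this assay.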